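Chloro to methylsulfanyl exchange across two related cores

This account rests on a few compounds, and the source may have more. Where it says the series, first, only, none or still open, it means among the compounds named here.

Measured so far in a functional assay on the whole organism for inhibition, with Brassica napus as the target, with a stated time of 72 h, tested at 100 mg/L; on this read-out higher numbers stand for more inhibition of growth at the one concentration tested and lower numbers for less inhibition of growth:
- compound 1, `CSc1cc(C)nc(NC(=S)NC(=O)c2c(-c3ccc(Cl)cc3Cl)noc2C)n1`: compound 1 gives 73.6%
- compound 2, `Cc1cc(Cl)nc(NC(=S)NC(=O)c2c(-c3ccc(Cl)cc3Cl)noc2C)n1`: compound 2 gives 50.8%
- compound 3, `COc1cc(Cl)nc2n/c(=N/C(=O)c3c(-c4ccc(Cl)cc4Cl)noc3C)sn12`: compound 3 gives 70.8%

Compound 1 and compound 2 share one core and differ in one place; the change is methylsulfanyl in place of chloro on an aromatic carbon, and in this assay it made the step of a number 22.8 percentage points higher from compound 2 to compound 1 (beyond the scatter). Compound 3 carries a different core, and the difference between the two cores is not broken down here; its value stands within the scatter of compound 1 and beyond the scatter above compound 2.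

Compound 4, `COc1cc(SC)nc2n/c(=N/C(=O)c3c(-c4ccc(Cl)cc4Cl)noc3C)sn12`, is not yet measured. It differs from compound 3 by methylsulfanyl in place of chloro on an aromatic carbon. This is the same kind of change as that from compound 2 to compound 1, not the same: around the place, compound 2 has the ring meta to a large group and meta to a methyl group, whereas in compound 3 the ring is part of a fused or bridged system of two rings, meta to a fused ring, para to a fused ring and meta to a methoxy group.

For compound 4 in this assay a rise is expected, resting on the step from compound 2 to compound 1 a number 22.8 percentage points higher from compound 2 to compound 1 (beyond the scatter), but a smaller one, because compound 3 already stands at 70.8% and the read-out cannot go far above it. The expected step is a number 13.2 percentage points higher from compound 3 to compound 4 (beyond the scatter). The estimate for compound 4 is 84%, between 68% and 97%. This rests on one pair only; compound 3 and compound 2 give no further check.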

Compound 4, percent growth inhibition at one concentration: 75.8%
Estimate against measurement, compound 4: 8.2 percentage points above; the range from low to high includes it.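

In this assay, methylsulfanyl in place of chloro on an aromatic carbon gives a number 5 percentage points higher from compound 3 to compound 4 (within the scatter), so on the core of compound 3 the exchange leaves no effect that can be told apart from repeat variation. The exchange therefore does not carry over at the same size from the core of compound 2 to the core of compound 3: the same change on two cores in this assay, a number 22.8 percentage points higher (beyond the scatter) from compound 2 to compound 1 and a number 5 percentage points higher (within the scatter) from compound 3 to compound 4, 17.8 percentage points apart, beyond the scatter of two such steps This shows that the step seen on one core cannot simply be transferred to the other in this series, but with a single pair on each core it does not show what sets the gap, nor does it give a rule for any further core.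

The compounds shown leave open how an amine, or a longer chain on the sulfur such as ethylsulfanyl, would read in place of the chloro on either core, and so whether the two cores also part ways for other exchanges at this place. They also leave open whether the methoxy group on the core of compound 3 bears on the size of the step, as no pair shown changes that group while the chloro or methylsulfanyl stays fixed.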